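Coumarin-triazole lipoate amides: methoxy on the pendant phenyl

A few compounds are considered here, and "the series" means these few. Any claim that something is new, unique, unknown or untested is made for them only; others in the source may bear on it.

Two members of the series have been run through a functional assay on PC-12 cells (Rattus norvegicus) for cytotoxicity, read by MTT assay, with stated times of 3 h and 2 h, tested at 1 uM (a higher number here means a stronger effect of the compound at the concentration tested, a lower number a weaker effect), so far. Compound 1, `CC(=O)c1cc2ccc(OCCCn3cc(CNC(=O)CCCCC4CCSS4)nn3)cc2oc1=O`, gives 35.5% in this assay. Compound 2, `O=C(CCCCC1CCSS1)NCc1cn(CCCOc2ccc3cc(-c4ccccc4)c(=O)oc3c2)nn1`, gives 31.9% in this assay. Among the compounds with values here, the single step between them, a number 3.6 percentage points lower from compound 1 to compound 2 (within the scatter), so compound 1 and compound 2 lie within the usual scatter of each other and no order between them can be read from these two numbers.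

Compound 3, `COc1ccc(-c2cc3ccc(OCCCn4cc(CNC(=O)CCCCC5CCSS5)nn4)cc3oc2=O)cc1`, is the next member to be measured. Its change from compound 2 is methoxy in place of hydrogen on an aromatic carbon.

Within the data shown here, no measured step touches this position; the one step in hand, phenyl in place of acetyl, was within the scatter, and nothing on the methoxy itself has been measured. On this basis no step beyond the scatter is expected, and the estimated step is a number 0.1 percentage points higher from compound 2 to compound 3 (within the scatter) in this assay. For compound 3 the estimate in this assay is therefore 32%, with a range from 21% to 43% that reflects the scatter of single-concentration readings rather than any trend.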

Compound 3, a percentage reported as activity, at one concentration (the size of the read-out at that concentration, not a potency): 47.4%
Compound 3: middle estimate off by 15.4 percentage points, on the low side, outside the stated range (above it).
By their numbers in this assay, from the lowest: compounds 2 and 1 (each within the scatter of the next); then compound 3.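

In this assay, within the data shown here, the pendant phenyl proves to be a position that responds: methoxy in place of hydrogen on an aromatic carbon, para to a large group, gives a number 15.5 percentage points higher from compound 2 to compound 3 (beyond the scatter) and so provides the first step that clears the scatter. The comparison with acetyl also changes once the methoxy is present, since 4-methoxyphenyl in place of acetyl gives a number 11.9 percentage points higher from compound 1 to compound 3 (beyond the scatter) while plain phenyl in place of acetyl gives only a number 3.6 percentage points lower from compound 1 to compound 2 (within the scatter) and leaves those two compounds unordered. The separation in this short series therefore appears only with the methoxy on the phenyl, and nothing in hand bears on the reason for it.

Still open, as far as these compounds go, is whether this rise belongs to methoxy specifically or would also appear with another group on the same carbon, such as a hydroxy, an amine, a fluorine or the longer ethoxy. Among these compounds, also open is whether the rise depends on this placement on the phenyl, and whether it holds at concentrations other than the one behind these readings.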